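From dimethylamino to benzyl(methyl)amino among assay limits

The source may report more compounds than this note shows. Statements on the series, on what has been measured and on what is new or still open speak of the compounds shown alone.

Measured in an ADME assay on BE(2)-C cells (Homo sapiens) for cytotoxicity, read by MTT assay, with a stated time of 20 h; a higher number here means that more compound is tolerated, a lower number that less compound is tolerated
- Compound 1 `Cn1ccc(CNC(=O)C2CCN(C(=O)c3cc4ccccc4n3Cc3ccc(Cl)cc3)CC2)n1` gives > 100000 nM, a limit
- Compound 2 `Cn1cnc(CNC(=O)C2CCN(C(=O)c3cc4ccccc4n3Cc3ccc(Cl)cc3)CC2)c1` gives > 50000 nM, a limit
- Compound 3 `CN(C)C(=O)C1CCN(C(=O)c2cc3ccccc3n2Cc2ccc(Cl)cc2)CC1` gives > 100000 nM, a limit

Compound 3 therefore offers no exact starting number, since its > 100000 nM is a limit. It sits at the limit of > 100000 nM in this assay, at which 2 of the 3 values shown sit.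

Compound 4 `CN(Cc1ccccc1)C(=O)C1CCN(C(=O)c2cc3ccccc3n2Cc2ccc(Cl)cc2)CC1` differs from compound 3 by one change: phenyl in place of hydrogen on a saturated chain carbon bound to an amide-type nitrogen. This places phenyl in place of hydrogen on a saturated chain carbon bound to an amide-type nitrogen, which also reads as methyl to benzyl.

Among the measured compounds shown here, two measured steps bear on this change, since each alters the same amide group: a step that the two limits leave unreadable from compound 1 to compound 3 and a step that the two limits leave unreadable from compound 2 to compound 3. Neither has a size that can be read, so neither supplies a number or a direction to carry over. The expectation in this assay is therefore no shift beyond the usual scatter, and another limit is quite likely. The expected change is a number no higher from compound 3 to compound 4 (the limit leaves the size open).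

The estimate for compound 4 is 100000 nM, with an expected range from 40000 nM to 200000 nM.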

Compound 4, half-maximal cytotoxic concentration: 87000 nM
Compound 4: middle estimate off by 1.1-fold (0.06 log units), on the high side; measured number inside the range.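

In this assay compound 4 gives 87000 nM, the first exact number among the compounds shown, so this amide nitrogen can carry a benzyl group and still leave a readable value. From the compounds shown here alone, the numbers show an at least 1.1-fold lower number from compound 3 to compound 4 (0.06 log units; that floor lies within the scatter) and an at least 1.1-fold lower number from compound 1 to compound 4 (0.06 log units; that floor lies within the scatter); both steps start from a limit, so these are floors and the true sizes stay unknown. The step between compound 2 and compound 4 cannot be read.

Going by these compounds, how far compound 4 really lies from compound 1 and compound 3 therefore stays open. Also open, on these data alone, is what this assay would give with a longer chain in place of the benzyl's single carbon link, or with an amine or a carboxylic acid in place of its phenyl.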